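The source may report more compounds than this note shows. Statements on the series, on what has been measured and on what is new or still open speak of the compounds shown alone.

Compound 1 `CCOC(=O)Cc1sc(-c2ccccc2)nc1O` has the higher of the two numbers in an assay on HEK293 cells for inhibition of transient receptor potential cation channel subfamily M member 8 (Homo sapiens), read by FLIPR, with stated times of 5 min and 3 min (a higher number here means a weaker inhibitor, a lower number a stronger inhibitor), where compound 1 gives 950 nM. Compound 2 `O=C(c1sc(-c2ccccc2O)nc1O)N1CCCCO1` gives 81 nM in this assay, a lower number that lies beyond the scatter. Compound 3 `CCOC(=O)c1sc(-c2ccccc2)nc1O` differs from compound 1 by ethoxycarbonyl in place of (ethoxycarbonyl)methyl on an aromatic carbon. Going by the values given here, no step between measured compounds carries this same change, so any expectation remains tentative. Compound 3 is expected to show a modest step toward a lower number, a 2.4-fold lower number from compound 1 to compound 3 (0.38 log units; beyond the scatter), which may not exceed the scatter. For compound 3 the estimate in this assay is 400 nM, with a range from 120 nM to 1500 nM.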

Compound 3, half-maximal inhibitory concentration: 32 nM
Compound 3: middle estimate off by 13-fold (1.10 log units), on the high side; the measured number lies below the stated range.
By their numbers in this assay, from the lowest: compound 3; then compound 2; then compound 1.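

In this assay, ethoxycarbonyl in place of (ethoxycarbonyl)methyl on this aromatic carbon, next to the ring sulfur, gives a 30-fold lower number from compound 1 to compound 3 (1.47 log units; beyond the scatter) in a single change. The position therefore responds strongly to a small change, since the two groups have the same counts of donors and acceptors and differ by one carbon. Nothing at hand accounts for the size of this step. Open, going by these compounds, is whether a carboxylic acid or a simple amide on this carbon would keep the low number. Also open, on these data alone, is how a propoxycarbonyl chain in place of ethoxycarbonyl would read.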